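From tert-butyl to 1-methylcyclopropyl: an exposure estimate

A few compounds are considered here, and "the series" means these few. Any claim that something is new, unique, unknown or untested is made for them only; others in the source may bear on it.

Compound 1 `Cc1ccc2c(c1)c(-c1ccc[nH]c1=O)c(C(=O)NS(=O)(=O)C1CC1)n2Cc1cc(F)ccc1F`: 4530 ng.h/mL
Compound 2 `CC(C)(C)c1ccc2c(c1)c(-c1ccc[nH]c1=O)c(C(=O)NS(=O)(=O)C1CC1)n2Cc1cc(F)ccc1F`: 4320 ng.h/mL

In an ADME assay on the whole organism (plasma) for pharmacokinetics, with Rattus norvegicus as the target, with a stated time of 24 h, at a dose of 10 mg/kg by the oral route (a higher number here means more compound in the circulation at the dose given, a lower number less compound in the circulation), compound 2 gives 4320 ng.h/mL, which lies within the scatter of compound 1 at 4530 ng.h/mL. The next structure, compound 3 `CC1(c2ccc3c(c2)c(-c2ccc[nH]c2=O)c(C(=O)NS(=O)(=O)C2CC2)n3Cc2cc(F)ccc2F)CC1`, keeps the core of compound 2 and carries 1-methylcyclopropyl in place of tert-butyl on an aromatic carbon. Within the data shown here, only one measured step bears on this change: a 1.0-fold lower number from compound 1 to compound 2 (0.02 log units; within the scatter), with tert-butyl in place of methyl on an aromatic carbon. Among the measured compounds shown here, a single step is thin evidence, and no measured compound yet carries the new ring. The expected step is a 1.0-fold lower number from compound 2 to compound 3 (0.01 log units; within the scatter), which means no change beyond the scatter is expected in this assay. For compound 3 the estimated value is 4200 ng.h/mL, with an expected range from 1900 ng.h/mL to 9000 ng.h/mL.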

Compound 3, area under the concentration-time curve: 5910 ng.h/mL
For compound 3 the middle estimate is 1.4-fold (0.15 log units) below the measured one; the measured number falls inside the stated range.
By their numbers in this assay, from the lowest: compounds 2, 1 and 3 (each within the scatter of the next).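

In this assay, swapping tert-butyl for 1-methylcyclopropyl gives a 1.4-fold higher number from compound 2 to compound 3 (0.14 log units; within the scatter), so bringing a three-membered non-aromatic ring of carbon only onto this aromatic carbon moves the number no further than the scatter. Set against the methyl group, the same ring gives a 1.3-fold higher number from compound 1 to compound 3 (0.12 log units; within the scatter), which places methyl, tert-butyl and 1-methylcyclopropyl all within the scatter of one another at this position. No measurement at hand offers any explanation for this flat result.

As far as these compounds go, all three groups here are made of carbon only, so how an amine, a carboxylic acid or a longer alkyl chain at this place would read in this assay remains open. The area under the curve alone also leaves unresolved how absorption and clearance each contribute to these numbers.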